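This account rests on a few compounds, and the source may have more. Where it says the series, first, only, none or still open, it means among the compounds named here.

Measured in an ADME assay on the whole organism (Rattus norvegicus, strain Sprague-Dawley) for pharmacokinetics, at a dose of 10 mg/kg by the oral route; a lower number here means that a smaller share of the oral dose reaches the circulation, a higher number that a larger share of the oral dose reaches the circulation:
- compound 1 `Cc1cc(C(F)(F)F)ccc1-c1cc2cnn([C@@H](CC(C)C)c3ccc(C(=O)NCCC(=O)O)cc3)c2cc1C` gives 51.9%
- compound 2 `Cc1cc(C(F)(F)F)ccc1-c1cc2cn([C@@H](CC(C)C)c3ccc(C(=O)NCCC(=O)O)cc3)nc2cc1C` gives 32.3%

Compound 1 holds the higher of these two numbers, and the gap down to compound 2 lies beyond the usual scatter. Compound 3 `Cc1cc2c(cnn2[C@@H](CC(C)C)c2ccc(C(=O)NCCC(=O)O)cc2)cc1-c1ccc(C(F)(F)F)cc1Cl` has not yet been measured. It differs from compound 1 at one place (chloro in place of methyl on an aromatic carbon), with chloro in place of methyl on an aromatic carbon, ortho to a large group and meta to a trifluoromethyl group. The 2-methyl-4-(trifluoromethyl)phenyl thus becomes 2-chloro-4-(trifluoromethyl)phenyl. Within the data shown here, no measured pair shows this swap, so the data give no direct guide to its size. The expectation is therefore a small step, slightly downward if anything and within the scatter, and the expected change is a number 3.9 percentage points lower from compound 1 to compound 3 (within the scatter) on this basis. For compound 3 the estimated value is 48% with an expected range from 30% to 66% in this assay when it is measured.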

Compound 3, oral bioavailability: 35.4%
Estimate against measurement, compound 3: 12.6 percentage points above; low and high end bracket the measured number.
By their numbers in this assay, from the lowest: compounds 2 and 3 (each within the scatter of the next); then compound 1.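

Chloro in place of methyl on this aromatic carbon gives, in this assay, a number 16.5 percentage points lower from compound 1 to compound 3 (beyond the scatter), the first direct reading of this swap. The position is therefore not indifferent: exchanging one heavy atom for another, with no ring, hydrogen-bond donor, hydrogen-bond acceptor or net charge entering or leaving, moves the number past the usual scatter, and of these two groups methyl gives the higher value here. No measurement available explains this drop.

Going by these compounds, whether a fluoro, methoxy or nitrile group on this carbon would match methyl or chloro remains open. Also open, on these data alone, is whether the same swap on the core of compound 2 would give a step of similar size and direction.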